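From a thiazole to a pyrazole at the shared core

This account rests on a few compounds, and the source may have more. Where it says the series, first, only, none or still open, it means among the compounds named here.

Measured so far:
compound 1, `CCc1c(OC)nc2nc(-c3noc(C)n3)c(Cl)n2c1C` — 10 mg/kg
compound 2, `CCc1c(OC)nc2nc(-c3nc(C)c(C)s3)cn2c1C` — > 50 mg/kg
compound 3, `C=CCc1c(OC)nc2nc(-c3nc(C)cs3)cn2c1C` — > 50 mg/kg

In a functional assay on the whole organism with Rattus norvegicus as the target (on this read-out lower numbers stand for an effect already at smaller amounts and higher numbers for an effect only at larger amounts of compound), compound 1 gives 10 mg/kg. For compound 2 the value > 50 mg/kg is a limit of the assay and not a number. Compound 3 likewise sits at a limit, > 50 mg/kg. Compound 2 thus stands at the limit of > 50 mg/kg in this assay, at which 2 of the 3 values shown sit, and only compound 1 shows a number at all.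

Compound 4, `CCc1c(OC)nc2nc(-c3cc(C)[nH]n3)cn2c1C`, differs from compound 2 in one place: 5-methyl-1H-pyrazol-3-yl in place of 4,5-dimethyl-1,3-thiazol-2-yl on an aromatic carbon. For the measured compounds named here, no step between two measured compounds corresponds to this exchange, so its size must be judged from the change alone. The five-membered aromatic ring with 2 hetero atoms is kept; the 1 hydrogen-bond donor is new. A step of modest size toward an effect at smaller amounts is expected, from compound 2 to compound 4 of about an at least 1.6-fold lower number from compound 2 to compound 4 (0.22 log units; that floor lies within the scatter), though compound 4 may well remain at a limit as well.

The estimate for compound 4 in this assay is 30 mg/kg, in the range from 10 mg/kg to 100 mg/kg.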

Compound 4, minimum effective dose: > 50 mg/kg
Compound 4 ended at the assay's limit (the forecaster's own chance of this, stated with the estimate: 60%); middle value at least 1.6-fold (0.22 log units) from the limit.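

No step can be read from compound 2 to compound 4, since both end at a limit in this assay and not at a number: the limit of > 50 mg/kg in this assay, at which 3 of the 4 values shown sit.

The compounds shown leave open whether 5-methyl-1H-pyrazol-3-yl in place of 4,5-dimethyl-1,3-thiazol-2-yl changes the effect at all.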